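Trimethoxyphenyl chalcone replaces tolyl analogue on pyrazolopyrimidine core

The compounds below may be only part of what the source reports. "The series", "measured", "known", "first", "only" and "open" are said of these compounds alone.

Measured compounds:
compound 1 `COc1ccc(/C=C/C(=O)c2cc(-c3cc(OC)c(OC)c(OC)c3)n3nc(-c4ccccc4)cc3n2)cc1OC`: 15300 nM
compound 2 `COc1ccc(-c2cc(C(=O)/C=C/c3cc(OC)c(OC)c(OC)c3)nc3cc(-c4ccccc4)nn23)cc1OC`: 14700 nM
compound 3 `COc1cc(-c2cc(C(=O)/C=C/c3ccc(C)cc3)nc3cc(-c4ccccc4)nn23)cc(OC)c1OC`: 21900 nM

All three were tested in a functional assay on DU-145 cells (Homo sapiens) for antiproliferative activity, read by MTT assay, with a stated time of 24 h; on this read-out lower numbers stand for stronger inhibition and higher numbers for weaker inhibition. Compound 1 gives 15300 nM, compound 2 gives 14700 nM and compound 3 gives 21900 nM. The three numbers fall within the usual scatter of one another, so compound 3 cannot be placed as either weaker or stronger than the other two.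

Compound 4 `COc1cc(/C=C/C(=O)c2cc(-c3cc(OC)c(OC)c(OC)c3)n3nc(-c4ccccc4)cc3n2)cc(OC)c1OC` has not yet been measured. It differs from compound 3 in that (3,4,5-trimethoxyphenyl in place of 4-methylphenyl on a double-bonded chain carbon bound to a double-bonded chain carbon). Going by the values given here, the one measured step that touches this position is a 1.4-fold higher number from compound 1 to compound 3 (0.16 log units; within the scatter), where an exchange between two methoxylated and methyl-bearing phenyl groups moved the number only within the scatter. Compound 2, which carries the 3,4,5-trimethoxyphenyl group on its chain with a differently arranged core, shows a number close to compound 1 and compound 3.

Compound 4 is therefore expected to show a 1.5-fold lower number from compound 3 to compound 4 (0.16 log units; within the scatter), a change not clearly beyond the scatter. Compound 4 is estimated at 15000 nM, in a range from 6000 nM to 38000 nM.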

Compound 4, half-maximal inhibitory concentration: 17900 nM
Compound 4: middle estimate off by 1.2-fold (0.08 log units), on the low side; the measured number falls inside the stated range.
By their numbers in this assay, from the lowest: compounds 2, 1, 4 and 3 (each within the scatter of the next).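

In this assay the exchange of 4-methylphenyl for 3,4,5-trimethoxyphenyl on a double-bonded chain carbon bound to a double-bonded chain carbon gives a 1.2-fold lower number from compound 3 to compound 4 (0.09 log units; within the scatter) and so stays within the scatter, although the entering group is the larger one and brings hydrogen-bond acceptors that the leaving group lacks. Methoxy in place of hydrogen on an aromatic carbon is just as silent, both on the chain-bound ring (a 1.2-fold higher number from compound 1 to compound 4 (0.07 log units; within the scatter)) and on the ring bound directly to the core (a 1.2-fold higher number from compound 2 to compound 4 (0.09 log units; within the scatter)), so the number has not clearly moved with any of the exchanges read so far. Nothing available accounts for this lack of response.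

From the compounds shown here alone, how an amine or a carboxylic acid on this phenyl ring would read remains open. So does the effect of replacing the phenyl group on the other side of the core, which all four compounds share.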